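This account rests on a few compounds, and the source may have more. Where it says the series, first, only, none or still open, it means among the compounds named here.

Values measured in a functional assay on HCT-116 cells (Homo sapiens) for cytotoxicity, read by fluorescence, with a stated time of 72 h; a lower number here means a stronger inhibitor, a higher number a weaker inhibitor:

- compound 1 `CSc1nc(NCc2ccc(-c3ccccn3)cc2)c2[nH]nc(C(C)C)c2n1`: 2800 nM
- compound 2 `CC(C)c1n[nH]c2c(NCc3ccc(-c4ccccn4)cc3)nc(S(C)(=O)=O)nc12`: 1140 nM
- compound 3 `CC(C)c1n[nH]c2c(NCc3ccc(-c4ccccn4)cc3)nc(N3CCCCC3CCO)nc12`: 142 nM

Compound 3, at 142 nM, has the lowest number of the three. It is separated from the others by an 8.0-fold lower number from compound 2 to compound 3 (0.90 log units; beyond the scatter) and a 20-fold lower number from compound 1 to compound 3 (1.29 log units; beyond the scatter).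

The next compound, compound 4 `CC(C)c1n[nH]c2c(NCc3ccc(-c4ccccn4)cc3)nc(NCCN)nc12`, carries (2-aminoethyl)amino in place of 2-(2-hydroxyethyl)piperidin-1-yl on an aromatic carbon, between two ring nitrogen atoms: (2-aminoethyl)amino in place of 2-(2-hydroxyethyl)piperidin-1-yl on an aromatic carbon.

All three measured steps concern this same carbon. Exchanging one sulfur-linked group for another gave a 2.5-fold lower number from compound 1 to compound 2 (0.39 log units; beyond the scatter), whereas the two exchanges that introduced 2-(2-hydroxyethyl)piperidin-1-yl gave the larger changes already noted. Compound 4 resembles compound 3 in having a nitrogen-linked group on this carbon, so its number is expected to stay closer to that of compound 3 than to that of compound 2 at 1140 nM. However, no measured compound carries an open-chain amine here, and the ring and hydroxyl of compound 3 are both lost, so some loss is expected. The expected result is a modest move to a higher number, estimated as a 2.5-fold higher number from compound 3 to compound 4 (0.39 log units; beyond the scatter). For compound 4 the estimate is 350 nM, with an expected range from 100 nM to 1100 nM.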

Compound 4, half-maximal inhibitory concentration: 227 nM
Estimate against measurement, compound 4: 1.5-fold (0.19 log units) above; the range from low to high includes it.
By their numbers in this assay, from the lowest: compounds 3 and 4 (each within the scatter of the next); then compound 2; then compound 1.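

In this assay the exchange of 2-(2-hydroxyethyl)piperidin-1-yl for (2-aminoethyl)amino gives a 1.6-fold higher number from compound 3 to compound 4 (0.20 log units; within the scatter), so at this aromatic carbon, between two ring nitrogen atoms, the two compounds cannot be told apart even though the entering group has no ring, no hydroxyl and fewer heavy atoms. The gain seen earlier with one nitrogen-linked group now appears with a second, quite different one: replacing the sulfur-linked groups gives a 5.0-fold lower number from compound 2 to compound 4 (0.70 log units; beyond the scatter) and a 12-fold lower number from compound 1 to compound 4 (1.09 log units; beyond the scatter), and among these four compounds both nitrogen-linked groups have lower numbers than both sulfur-linked groups, with no compound going against this. Nothing measured here accounts for this difference between the nitrogen-linked and sulfur-linked groups.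

Going by these compounds, whether a chain ending in a hydroxyl or a methyl group in place of the terminal amine, or a longer chain such as (3-aminopropyl)amino, would keep the number in this range remains open. On these data alone, it is equally open what a plain piperidin-1-yl would give, which would separate the ring from the hydroxyethyl chain of compound 3.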